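Bromine on the Carbamate Ring and Macrophage Tolerance

This account rests on a few compounds, and the source may have more. Where it says the series, first, only, none or still open, it means among the compounds named here.

Three compounds sharing one core were tested in an ADME assay on RAW264.7 cells (Mus musculus) for cytotoxicity, read by MTT assay, with a stated time of 18 h; a higher number here means that more compound is tolerated, a lower number that less compound is tolerated. Compound 3 `C=C1C(=O)OC[C@H]1CCOC(=O)Nc1ccccc1` gives 14800 nM, and compound 2 `C=C1C(=O)OC[C@@H]1CCOC(=O)Nc1ccccc1` gives 22300 nM. The two differ only in configuration as drawn: the two compounds have the same atoms and bonds and differ only in configuration as drawn: 1 of 1 stereo elements differ; a stereocentre at a saturated ring carbon is drawn S in compound 3 and R in compound 2. The step of a 1.5-fold lower number from compound 2 to compound 3 (0.18 log units; within the scatter) is small, and the fact that the two differ only in how the stereocentre is drawn the fact that compounds 2 and 3 differ only in the configuration as drawn is the one thing known about that pair. Compound 1 `C=C1C(=O)OC[C@H]1CCOC(=O)Nc1cccc(Br)c1` is the brominated counterpart of compound 3, and in this assay compound 1 gives 21800 nM. The difference between compounds 3 and 1 is bromo in place of hydrogen on an aromatic carbon, and the measured step is a 1.5-fold higher number from compound 3 to compound 1 (0.17 log units; within the scatter), so the bromo group left the tolerated concentration essentially unchanged.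

Compound 4 `C=C1C(=O)OC[C@@H]1CCOC(=O)Nc1ccc(Br)cc1` has not yet been measured. It stands to compound 2 as compound 1 stands to compound 3 in kind: bromo in place of hydrogen on an aromatic carbon. The change is the same kind of change, not the same change, since the bromo sits meta to a large group in compound 1 but para to a large group in compound 4. Resting on the single measured instance of a bromo entering, the step from compound 2 to compound 4 in this assay is expected to be about a 1.1-fold higher number from compound 2 to compound 4 (0.05 log units; within the scatter), beside the earlier one. Compound 4 is therefore estimated at 25000 nM, between 12000 nM and 50000 nM.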

Compound 4, half-maximal cytotoxic concentration: 19800 nM
The estimate for compound 4 lay 1.3-fold (0.10 log units) above the measured number; low and high end bracket the measured number.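

The new step, a 1.1-fold lower number from compound 2 to compound 4 (0.05 log units; within the scatter), is as small as the earlier one, a 1.5-fold higher number from compound 3 to compound 1 (0.17 log units; within the scatter), so in this assay bromo in place of hydrogen on an aromatic carbon gave no readable change on either core. Carried from one core to the other, the change therefore looks the same in this assay, with no difference between the two steps that can be told from scatter: the same change on two cores in this assay, a 1.5-fold higher number (0.17 log units; within the scatter) from compound 3 to compound 1 and a 1.1-fold lower number (0.05 log units; within the scatter) from compound 2 to compound 4, 1.7-fold (0.22 log units) apart, within the scatter of two such steps. This does not show that a step of real size would carry over, since neither step is large enough to follow, and the bromo does not sit in the same place in the two pairs, being para to a large group only in compound 4, while the two cores are themselves close relatives, so place and drawn configuration cannot be told apart here: the fact that compounds 2 and 3 differ only in the configuration as drawn.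

The compounds shown leave open whether another group on the same aromatic ring, such as a chloro group, a methoxy group or an amine, would move the tolerated concentration beyond the scatter. They also leave open what would follow from replacing the carbamate with an amide or from a longer chain between the shared core and the carbamate.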